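Thiophene Replaces Fluorine on the Aryl Ring of Compound 2

The source may report more compounds than this note shows. Statements on the series, on what has been measured and on what is new or still open speak of the compounds shown alone.

Three compounds with a shared core were tested in a functional assay on cells for inhibition of Polyunsaturated fatty acid 5-lipoxygenase (Homo sapiens); on this read-out lower numbers stand for stronger inhibition and higher numbers for weaker inhibition. Compound 1 `CSc1cccc(N2CCNC(=O)N2)c1` gives 2200 nM, compound 2 `CC1CN(c2cccc(F)c2)NC(=O)N1` gives 1800 nM, and compound 3 `COc1cccc(N2CCNC(=O)N2)n1` gives 3500 nM. Compound 2 carries the lowest of the three numbers, but its gaps to compound 1 and to compound 3 both lie within the scatter, so the three cannot be ranked against each other. Compound 4 `CC1CN(c2cccc(-c3cccs3)c2)NC(=O)N1` differs from compound 2 in one place: thiophen-2-yl in place of fluoro on an aromatic carbon. Going by the values given here, no measured pair shows this change, so the data give no direct guide to its size. A modest move toward stronger inhibition is expected, as a 2.0-fold lower number from compound 2 to compound 4 (0.30 log units; within the scatter). Compound 4 is therefore estimated at 900 nM in this assay, with a range from 300 nM to 3000 nM.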

Compound 4, half-maximal inhibitory concentration: 5500 nM
Compound 4: middle estimate off by 6.1-fold (0.79 log units), on the low side; the whole stated range lies below it.
By their numbers in this assay, from the lowest: compounds 2, 1, 3 and 4 (each within the scatter of the next, the first and the last beyond it).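

Thiophen-2-yl in place of fluoro on this aromatic carbon gives a 3.1-fold higher number from compound 2 to compound 4 (0.49 log units; beyond the scatter) in this assay, the only step here and one that lies beyond the scatter. The position therefore responds to what it carries, and this five-membered aromatic ring goes with weaker inhibition than fluoro does. Nothing measured here accounts for the step. As far as these compounds go, whether phenyl, a methyl group, an amine or a carboxylic acid on this carbon would go the same way remains open, and so does whether thiophen-2-yl would have the same effect on the core of compound 1.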